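A few compounds are considered here, and "the series" means these few. Any claim that something is new, unique, unknown or untested is made for them only; others in the source may bear on it.

Series notes. In an ADME assay on MT4 cells (Homo sapiens) for cytotoxicity, read by MTT assay, with a stated time of 4 days (on this read-out lower numbers stand for higher toxicity in this test and higher numbers for lower toxicity in this test), compound 1 `CCOc1cc(C#N)cc(OCC)c1Oc1nc(Nc2ccc(C#N)cc2)nc2ccccc12` gives 108000 nM. Compound 3 `CCCOc1cc(C#N)cc(OCC)c1Oc1nc(Nc2ccc(C#N)cc2)nc2ccccc12` carries methyl in place of hydrogen on a saturated chain carbon, two bonds along the chain from an oxygen on an aromatic ring; in this assay compound 3 gives 123000 nM, and the step of a 1.1-fold higher number from compound 1 to compound 3 (0.06 log units; within the scatter) is within the scatter. Compound 2 `Cc1cc(Br)c(Oc2nc(Nc3ccc(C#N)cc3)nc3ccccc23)c(Br)c1` gives 25000 nM in this assay, the lowest of the three numbers, with compound 1 nearest and compound 3 furthest, both gaps beyond the scatter.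

Compound 4 `N#Cc1ccc(Nc2nc(Oc3c(Cl)cc(Cl)cc3Cl)c3ccccc3n2)cc1` is not yet measured. It differs from compound 2 by 2,4,6-trichlorophenyl in place of 2,6-dibromo-4-methylphenyl on an oxygen on an aromatic ring. Within the data shown here, no measured step touches the group on this oxygen: the only step in hand, a 1.1-fold higher number from compound 1 to compound 3 (0.06 log units; within the scatter), changes a chain elsewhere and stays within the scatter, so it carries no information about an exchange of the group on the oxygen. Compound 1 and compound 2 differ from one another in more than one place, so their gap cannot be assigned to any single change. Among the measured compounds shown here, with no bearing step, no movement beyond the scatter is expected, and the step of no change at the digits printed from compound 2 to compound 4 (within the scatter) is expected to stay within it. Compound 4 is estimated at 25000 nM, with a range from 8000 nM to 80000 nM.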

Compound 4, half-maximal cytotoxic concentration: 56000 nM
Estimate against measurement, compound 4: 2.2-fold (0.35 log units) below; the measured number falls inside the stated range.
By their numbers in this assay, from the lowest: compound 2; then compounds 4, 1 and 3 (each within the scatter of the next, the first and the last beyond it).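

In this assay, among these compounds, 2,4,6-trichlorophenyl in place of 2,6-dibromo-4-methylphenyl on an oxygen on an aromatic ring gives a 2.2-fold higher number from compound 2 to compound 4 (0.35 log units; beyond the scatter), the first single change to pass the scatter and the first to touch the group at this place. The read-out therefore responds to the group on this oxygen, even though the groups that leave and enter count the same heavy atoms and each holds one six-membered aromatic ring of carbon only. No measured property of these compounds bears on this step, so the change stands as an observation without an explanation.

The exchange replaces both bromine atoms and the methyl at once, so this step cannot say how much of the movement belongs to either part. Also open, on these data alone, is how the number would respond to fluorine, an amine or a carboxylic acid on this ring, and whether a step of this size would carry over to the ring bearing the ethoxy and nitrile groups of compound 1.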